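Swapping the fluorophenyl for a vinyl group

The source may report more compounds than this note shows. Statements on the series, on what has been measured and on what is new or still open speak of the compounds shown alone.

Compound 1 `COc1ccc(-c2nc(-c3c[nH]c4ccccc34)co2)cc1OC` gives 300000 nM in a functional assay on DU-145 cells (Homo sapiens) for cytotoxicity, read by MTT assay, with a stated time of 48 h; a lower number here means a stronger inhibitor, a higher number a weaker inhibitor. Compound 2 `Fc1ccc(-c2nc(-c3c[nH]c4ccccc34)co2)cc1` gives 31800 nM. Compound 3 `c1ccc2c(-c3cocn3)c[nH]c2c1` gives 93500 nM.

Among these three numbers compound 2 stands lowest. The nearest is compound 3, reached by the step of a 2.9-fold higher number from compound 2 to compound 3 (0.47 log units; beyond the scatter), in which the 4-fluorophenyl is taken off and only a hydrogen remains on the shared core. Compound 1, which carries a dimethoxyphenyl instead, gives the highest number of the three, well beyond the scatter from compound 2.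

Compound 4 `C=Cc1nc(-c2c[nH]c3ccccc23)co1` has not yet been measured. It differs from compound 2 in one place: vinyl in place of 4-fluorophenyl on an aromatic carbon. Among the compounds with values here, the only measured step that speaks to this change is a 2.9-fold higher number from compound 2 to compound 3 (0.47 log units; beyond the scatter), where losing the whole aromatic ring raised the number modestly. A vinyl is neither the full ring nor a bare hydrogen, so the expected outcome lies between the two measured points, tending toward a higher number than compound 2 shows in this assay. Compound 4 is therefore estimated at 60000 nM, with a likely range from 25000 nM to 150000 nM. That estimate corresponds to an expected step of a 1.9-fold higher number from compound 2 to compound 4 (0.28 log units; within the scatter), a rise of about the same size as the one seen when the ring was removed altogether.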

Compound 4, half-maximal inhibitory concentration: 59800 nM
Estimate against measurement, compound 4: 1.0-fold (0.00 log units) above; low and high end bracket the measured number.
By their numbers in this assay, from the lowest: compounds 2, 4 and 3 (each within the scatter of the next, the first and the last beyond it); then compound 1.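

The change from 4-fluorophenyl to vinyl gives a 1.9-fold higher number from compound 2 to compound 4 (0.27 log units; within the scatter) and the change from hydrogen to vinyl gives a 1.6-fold lower number from compound 3 to compound 4 (0.19 log units; within the scatter). In this assay compound 4 therefore cannot be told apart from either compound 2 or compound 3, even though those two lie beyond the scatter of each other, so the vinyl compound fills the gap without settling which side it belongs to. This also shows something new about the position on the five-membered aromatic ring: a group with no ring can stay within the scatter of the compound that carries the six-membered aromatic ring, which the bare hydrogen of compound 3 did not do, but no measurement at hand explains why these numbers fall as they do.

The compounds shown leave open whether the double bond of the vinyl matters at all, a question that an ethyl group at the same place would address. They also leave open whether an amine or a carboxylic acid there would move the number beyond the scatter of compound 2, and in which direction.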